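Cytotoxicity of a bis-amidine series: from chloro to methoxymethyl

The source may report more compounds than this note shows. Statements on the series, on what has been measured and on what is new or still open speak of the compounds shown alone.

Compound 1, `COCc1c(-c2ccc(C(=N)N)cc2)oc(-c2ccc(C(=N)N)cc2)c1Cl`, gives 209000 nM in an ADME assay on HEK293 cells (Homo sapiens) for cytotoxicity, read by resazurin assay, with a stated time of 24 h; a higher number here means a weaker inhibitor, a lower number a stronger inhibitor.
Compound 2, `CC(C)OCc1c(-c2ccc(C(=N)N)cc2)oc(-c2ccc(C(=N)N)cc2)c1COC(C)C`, gives > 50000 nM in this assay, which is a limit of the assay and not a number.
Compound 3, `CCN(CC)CCN=C(Nc1ccc(C(=N)N)cc1)Nc1ccc(C(=N)N)cc1`, gives > 50000 nM in this assay, again a limit of the assay.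

Among the measured compounds shown here, compound 1 is the only member of the set for which this assay reports a number at all; the other two values stop at the limit, so no ranking among the three can be drawn, and no step between measured compounds is available. Compound 4, `COCc1c(-c2ccc(C(=N)N)cc2)oc(-c2ccc(C(=N)N)cc2)c1COC`, shares the core of compound 1 and differs from it in one place: methoxymethyl in place of chloro on an aromatic carbon. With only the limit of > 50000 nM in this assay, at which 2 of the 3 values shown sit, as a guide, the account expects compound 4 to remain weak in this assay, with the step of a 1.4-fold lower number from compound 1 to compound 4 (0.14 log units; within the scatter) likely no larger than the scatter and in no set direction. The estimate for compound 4 in this assay is 150000 nM, within 50000 nM to 400000 nM, with a fair chance that only a limit is reported.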

Compound 4, half-maximal inhibitory concentration: > 50000 nM
Compound 4: no number, only a limit; the forecaster's own chance of this, stated with the estimate: 60%; the middle value is on the limit's open side.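

In this assay compound 4 gives > 50000 nM, a limit of the assay and not a number. Among the compounds shown here, no step from compound 1 to compound 4 can be read. The compounds shown leave open how far methoxymethyl in place of chloro on an aromatic carbon moves the number, and how compound 2, compound 3 and compound 4 rank among themselves.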